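The source may hold more compounds than are shown below. What is called first, only, known or untested is meant among the compounds shown, and "the series" means these compounds.

Measured compounds:
compound 1, `COc1ccc(-c2cn3ccnc3c(-c3ccc4ncn(C5CCCCC5)c4c3)n2)cc1`, 92.5% in a functional assay on SF-295 cells (Homo sapiens) for inhibition, read by sulforhodamine B assay, with a stated time of 48 h, tested at 10 uM; a higher number here means more inhibition at the concentration tested (going by the name of the read-out), a lower number less inhibition;
compound 2, `Fc1ccc(-c2cn3ccnc3c(-c3ccc4ncn(C5CCCCC5)c4c3)n2)cc1`, 7.93%.

Compound 2 holds the lower of the two numbers seen in this assay; its nearest neighbour is compound 1, whose number lies far higher. Among the measured compounds shown here, the only step between measured compounds is a number 84.6 percentage points lower from compound 1 to compound 2 (beyond the scatter), and it is large. Compound 3, `Clc1ccc(-c2cn3ccnc3c(-c3ccc4ncn(C5CCCCC5)c4c3)n2)cc1`, is not yet measured. It differs from compound 2 in one place: chloro in place of fluoro on an aromatic carbon.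

For the measured compounds named here, no measured step exchanges one halogen for another, so the step from compound 2 to compound 3 has no direct counterpart. The step from compound 1 to compound 2 bears on it only indirectly: it shows that the group at this place alone moves the read-out across almost its whole span, so a change at the same place could again be large. Which direction a chloro will take the number cannot be told from two compounds. The estimate for compound 3 is therefore 30%, within a wide range from 5% to 75%, which as a step is expected to be a number 22.1 percentage points higher from compound 2 to compound 3 (beyond the scatter).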

Compound 3, a percentage reported as inhibition, at one concentration (the size of the read-out at that concentration, not a potency): 14.5%
Compound 3: middle estimate off by 15.5 percentage points, on the high side; the measured number falls inside the stated range.
By their numbers in this assay, from the lowest: compounds 2 and 3 (each within the scatter of the next); then compound 1.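

In this assay, one halogen exchanged for another at this place, on the six-membered aromatic ring para to a large group, gives a number 6.6 percentage points higher from compound 2 to compound 3 (within the scatter) and so leaves 4-fluorophenyl and 4-chlorophenyl indistinguishable in this read-out. The low number is therefore no longer tied to fluoro alone: alongside a number 84.6 percentage points lower from compound 1 to compound 2 (beyond the scatter) there now stands a number 78 percentage points lower from compound 1 to compound 3 (beyond the scatter) and thus two different halogens sit far from the methoxy of compound 1. Why methoxy stands so far from both halogens remains unexplained, as no supporting data on the cause are available.

On these data alone, it remains open whether the high number belongs to methoxy alone or is shared by other groups at this place, such as a hydroxyl, an amine, an ethoxy or a longer alkoxy chain, and whether a bromo or a methyl would fall with the two halogens. Also open, as far as these compounds go, is whether the same gap between methoxy and the halogens would hold if the cyclohexyl on the shared core were replaced by another group, such as a cyclopentyl or a piperidine.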